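The source may hold more compounds than are shown below. What is called first, only, known or untested is meant among the compounds shown, and "the series" means these compounds.

Measured in a functional assay on HeLa cells (Homo sapiens) for antiproliferative activity, read by MTT assay, with a stated time of 72 h; on this read-out lower numbers stand for stronger inhibition and higher numbers for weaker inhibition:
- compound 1 `CCCCn1ccnc1-c1cc(OC)c(OC)c(OC)c1`: > 100000 nM, a limit
- compound 2 `COc1cc(-c2nccn2CC(C)C)cc(OC)c1OC`: > 100000 nM, a limit
- compound 3 `COc1cc(-c2nccn2-c2ccc(C)cc2)cc(OC)c1OC`: 700 nM

Compound 3 is the only one of the three with a true number, 700 nM. Compound 4 `COc1cccc(-n2ccnc2-c2cc(OC)c(OC)c(OC)c2)c1` carries 3-methoxyphenyl in place of 4-methylphenyl on an aromatic nitrogen.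

Two large steps, both beyond the scatter, bear on this: an at least 140-fold lower number from compound 1 to compound 3 (2.15 log units; beyond the scatter) and an at least 140-fold lower number from compound 2 to compound 3 (2.15 log units; beyond the scatter). Each swaps a saturated chain for 4-methylphenyl. Going by the values given here, compound 4 keeps a six-membered aromatic ring on that nitrogen, and no measured step changes a group on that ring. So no step beyond the scatter is expected: the expected step is a 1.4-fold higher number from compound 3 to compound 4 (0.15 log units; within the scatter). The estimate for compound 4 is 1000 nM, with an expected range from 200 nM to 6000 nM.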

Compound 4, half-maximal inhibitory concentration: 11000 nM
For compound 4 the middle estimate is 11-fold (1.04 log units) below the measured one; measured number outside the range, above it.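

In this assay, an aromatic ring on this nitrogen is not enough by itself: 3-methoxyphenyl in place of 4-methylphenyl gives a 16-fold higher number from compound 3 to compound 4 (1.20 log units; beyond the scatter), so what that ring carries matters. The ring of compound 4 still beats both saturated chains, with an at least 9.0-fold lower number from compound 2 to compound 4 (0.95 log units; beyond the scatter) and an at least 9.0-fold lower number from compound 1 to compound 4 (0.95 log units; beyond the scatter). These two steps are minimum sizes only because compound 1 and compound 2 each stand at a limit: the limit of > 100000 nM in this assay, at which 2 of the 4 values shown sit.

Compound 3 and compound 4 differ in both the group on the ring and where it sits, so the two changes cannot be told apart. Going by these compounds, how a ring carrying an amine or a carboxylic acid would read remains open.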